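A few compounds are considered here, and "the series" means these few. Any claim that something is new, unique, unknown or untested is made for them only; others in the source may bear on it.

In an ADME assay for permeability, using PAMPA, at pH 4 (a higher number here means that the compound crosses the layer faster, a lower number that the compound crosses the layer more slowly), the measured compounds are:
- compound 1 `COc1cc2[nH]c(C)c(C3CCCCC3)c(=O)c2cc1Cl`: 1240 10^-6 cm/s
- compound 2 `CCCCC#Cc1c(C)[nH]c2cc(OC)c(Cl)cc2c1=O`: 148 10^-6 cm/s

Compound 2, at 148 10^-6 cm/s, holds the lower of these two numbers, and compound 1 lies beyond the scatter above it. The next compound to be measured is compound 3 `C=C(CCCCC)c1c(C)[nH]c2cc(OC)c(Cl)cc2c1=O`, which departs from compound 2 on an aromatic carbon: a group of 7 heavy atoms (7 carbon; no ring) in place of a group of 6 heavy atoms (6 carbon; no ring), on an aromatic carbon. Among the measured compounds shown here, only one measured step bears on this change: an 8.4-fold lower number from compound 1 to compound 2 (0.92 log units; beyond the scatter). That modest step lies beyond the scatter and records hex-1-yn-1-yl in place of cyclohexyl. Compound 3 also gives up hex-1-yn-1-yl, so some return toward compound 1, at 1240 10^-6 cm/s, is expected in this assay. The entering group has no ring, unlike cyclohexyl, so only part of that distance is expected to be recovered. With a single step as a guide, this expectation remains loose. The expected change is a 3.2-fold higher number from compound 2 to compound 3 (0.51 log units; beyond the scatter), a rise estimated to lie beyond the scatter. For compound 3 the estimated value is 480 10^-6 cm/s, with an expected range from 170 10^-6 cm/s to 1350 10^-6 cm/s.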

Compound 3, apparent permeability: 768 10^-6 cm/s
Compound 3: the middle estimate sits 1.6-fold (0.20 log units) below what was measured, and the stated range covers the measured number.
By their numbers in this assay, from the lowest: compound 2; then compounds 3 and 1 (each within the scatter of the next).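

In this assay the change from hex-1-yn-1-yl to the seven-carbon group with a double bond gives a 5.2-fold higher number from compound 2 to compound 3 (0.72 log units; beyond the scatter) and shows that the low number of compound 2 does not extend to every ring-free group on this aromatic carbon. Among the compounds shown here, the second comparison, a 1.6-fold lower number from compound 1 to compound 3 (0.21 log units; within the scatter), places compound 3 within the scatter of compound 1, so that in this small set the cyclohexyl ring is not needed for a number of that order, which the single step available earlier could not reveal. Nothing available explains why the triple-bonded chain stands apart from the other two groups.

The step from compound 2 to compound 3 alters the heavy-atom count and replaces a triple bond with a double bond in a single move, leaving the share of each change unresolved. The compounds shown also leave open how a fully saturated chain such as hexyl, a shorter chain such as butyl, or a chain ending in an amine or a carboxylic acid would behave at this position in this assay.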